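The compounds below may be only part of what the source reports. "The series", "measured", "known", "first", "only" and "open" are said of these compounds alone.

In a functional assay on UACC-62 cells (Homo sapiens) for cytotoxicity, read by sulforhodamine B assay (a higher number here means a weaker inhibitor of growth, a lower number a stronger inhibitor of growth), compound 1 `CC1=CC[C@@H]([C@@](C)(O)CCCC(C)(C)NC=S)CC1` gives 9960 nM and compound 2 `COc1ccc(/C=N\NC(=S)NC(C)(C)CCC[C@](C)(O)[C@@H]2CC=C(C)CC2)cc1` gives 7420 nM, two values within the scatter of each other. Compound 3 `CC1=CC[C@@H]([C@@](C)(O)CCCC(C)(C)NC(=S)N/N=C\c2ccc(N(C)C)cc2)CC1` reads > 100000 nM, which is a limit of the assay and not a number. Within the data shown here, compound 2 therefore shares the only two true numbers with compound 1, with no order between them.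

Compound 4 `CC1=CC[C@@H]([C@@](C)(O)CCCC(C)(C)NC(=S)N/N=C\c2ccc([N+](=O)[O-])cc2)CC1` differs from compound 2 as follows: nitro in place of methoxy on an aromatic carbon. This places nitro in place of methoxy on an aromatic carbon, para to a large group.

The only measured replacement of this methoxy is an at least 13-fold higher number from compound 2 to compound 3 (1.12 log units; beyond the scatter), a large step beyond the scatter. That single step involves a different entering group, so it offers only weak guidance on size. A modest rise in the number is expected in this assay, much smaller than that step and possibly within the scatter. The estimated step is a 1.6-fold higher number from compound 2 to compound 4 (0.21 log units; within the scatter). For compound 4 the expected value is 12000 nM, with an estimated range of 3000 nM to 60000 nM.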

Compound 4, concentration for 50% growth inhibition: 20800 nM
For compound 4 the middle estimate is 1.7-fold (0.24 log units) below the measured one; the range from low to high includes it.
By their numbers in this assay, from the lowest: compounds 2 and 1 (each within the scatter of the next); then compound 4. At a limit, above all of these: compound 3.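

In this assay, among these compounds, there is a 2.8-fold higher number from compound 2 to compound 4 (0.45 log units; beyond the scatter) and this is the first true number for a replacement of the methoxy on this aromatic carbon, para to a large group. Nitro therefore costs some growth inhibition beyond the scatter but leaves a measurable value, and there is also an at least 4.8-fold lower number from compound 3 to compound 4 (0.68 log units; beyond the scatter) so the two groups that replace methoxy do not read alike. From the compounds shown here alone, compound 3 stays a limit of the assay and not a number, so the true size of that second gap remains unknown: the limit of > 100000 nM in this assay, at which 1 of the 4 values shown sits.

With only methoxy, nitro and dimethylamino at this place, the compounds shown do not tell how a halogen such as chlorine, a carboxylic acid or a primary amine would read here. Going by these compounds, whether the same differences hold in other cell lines also stays open.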